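This account rests on a few compounds, and the source may have more. Where it says the series, first, only, none or still open, it means among the compounds named here.

Measured compounds:
compound 1 `Cc1ccccc1-n1nc(C)c2c1NC(=O)[C@H](C)S[C@@H]2c1ccc(-c2ccoc2)cc1` – 40%
compound 2 `CCc1ccccc1-n1nc(C)c2c1NC(=O)[C@H](C)S[C@@H]2c1ccc(Oc2ccccc2)cc1` – 190%
compound 3 `Cc1nn(-c2ccccc2F)c2c1C(c1ccc(Oc3ccccc3)cc1)SC(C)C(=O)N2` – 72%

In an assay on isolated protein for agonist activity at Bile acid receptor (Homo sapiens), read by AlphaScreen, with a stated time of 30 min (on this read-out higher numbers stand for larger maximal responses and lower numbers for smaller maximal responses), compound 2 gives 190%, the highest of the three numbers; compound 3 sits below it by a gap beyond the scatter, and compound 1 lies furthest below, also beyond the scatter. Compounds 1 and 3 differ from compound 2 in more than one place, so these gaps cannot be tied to a single change.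

Compound 4 `Cc1nn(-c2ccccc2C(C)C)c2c1[C@@H](c1ccc(Oc3ccccc3)cc1)S[C@@H](C)C(=O)N2` is not yet measured. It differs from compound 2 by methyl in place of hydrogen on a saturated chain carbon bound to an aromatic carbon and a saturated chain carbon. Going by the values given here, no pair of measured compounds shows this change on its own, so nothing fixes its size. The expectation in this assay is a modest downward step, possibly no larger than the scatter, since compound 2 already gives 190%. For compound 4 the estimate is 155% with a range of 75% to 235%, which means an expected step of a number 35 percentage points lower from compound 2 to compound 4 (beyond the scatter).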

Compound 4, largest response reached (reported as efficacy), in percent of the reference or control that the assay uses: 174%
Compound 4: the middle estimate sits 19 percentage points below what was measured; the range from low to high includes it.
By their numbers in this assay, from the lowest: compound 1; then compound 3; then compound 4; then compound 2.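

In this assay, going by these compounds alone, the change from 2-ethylphenyl to 2-isopropylphenyl gives a number 16 percentage points lower from compound 2 to compound 4 (beyond the scatter), the only step that can be read at a single place. The position therefore accepts the added methyl with a large maximal response retained, as compound 4 stays at 174%. No measurement bears on why the step has this size.

Going by these compounds, whether a tert-butyl group, a longer chain or an amine at this place would retain that response remains open. A single step also leaves open whether the same change has a similar effect in other compounds of the series.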